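Swapping a chloro for a methyl on a benzoate ester

The compounds below may be only part of what the source reports. "The series", "measured", "known", "first", "only" and "open" are said of these compounds alone.

Measured compounds:
- compound 1, `CC1=CC[C@H](C(C)C)c2cc(C)c(OC(=O)c3ccc(Cl)cc3)cc21`: 25.6%
- compound 2, `Cc1cc2c(C(C)C)ccc(C)c2cc1OC(=O)c1ccc(C(F)(F)F)cc1`: 16.5%
- compound 3, `CC1=CC[C@H](C(C)C)c2cc(C)c(OC(=O)c3cccc(C(F)(F)F)c3)cc21`: 29.3%

All three compounds are esters of a shared core with a substituted benzoic acid, tested in a functional assay on U-251 cells (Homo sapiens) for antiproliferative activity, read by sulforhodamine B assay, with a stated time of 48 h, tested at 50 uM; on this read-out higher numbers stand for more inhibition at the one concentration tested (going by the name of the read-out) and lower numbers for less inhibition. Compound 1 carries a 4-chlorophenyl group and gives 25.6% in this assay. Its number sits in the middle of the three, but only within the scatter: compound 3, with a trifluoromethyl on the other ring, gives 29.3%, and compound 2, built on a different core, gives 16.5%. Neither gap from compound 1 is large enough to count as a real difference, so the three compounds cannot be ranked against each other on these numbers.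

Compound 4, `CC1=CC[C@H](C(C)C)c2cc(C)c(OC(=O)c3ccc(C)cc3)cc21`, has not yet been tested in this assay. It differs from compound 1 in one place: methyl in place of chloro on an aromatic carbon. In words of the structures, the 4-chlorophenyl becomes a 4-methylphenyl; the ester, the core and everything else stay the same.

For the measured compounds named here, no pair of measured compounds shows what this exact swap does. Going by the values given here, with only three numbers and all of them close together, the expected step in this assay is small, most likely none beyond the scatter, perhaps a slight drift downward. The expected value for compound 4 is 22%, with a range from 10% to 36%, which means an expected step of a number 3.6 percentage points lower from compound 1 to compound 4 (within the scatter).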

Compound 4, a percentage reported as inhibition, at one concentration (the size of the read-out at that concentration, not a potency): 67.7%
Compound 4: the middle estimate sits 45.7 percentage points below what was measured; measured number above the stated range.
By their numbers in this assay, from the lowest: compounds 2, 1 and 3 (each within the scatter of the next, the first and the last beyond it); then compound 4.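

The step of a number 42.1 percentage points higher from compound 1 to compound 4 (beyond the scatter) in this assay shows that this place on the benzoate ring is far from indifferent: with the ester and the shared core unchanged, exchanging one heavy atom for another moves the read-out well beyond the scatter. The earlier compounds shown here held no pair differing in one place, so they could not show this, and the simple counts do not separate the two groups, since chloro and methyl each have one heavy atom, no hydrogen-bond donors or acceptors and no net charge. No measurement here bears on the reason for this step.

On these data alone, it remains open whether the gain belongs to methyl alone or extends to other groups at the same place, such as an ethyl, a methoxy or an amine, and how a plain unsubstituted benzoate would compare. As far as these compounds go, it is also open whether the same swap would act similarly on the core of compound 2, and how compound 4 would behave across a range of concentrations, since a reading at one concentration is not a potency.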